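Thiophen-3-yl in place of cyclobutyl at the ring amine

The compounds below may be only part of what the source reports. "The series", "measured", "known", "first", "only" and "open" are said of these compounds alone.

Compound 2 `COc1cc(N)c(Cl)cc1NC(=O)C1CCN(CC2CCC2)CC1` stands only at a limit in a functional assay on the whole organism for antagonist activity, with Mus musculus as the target; a lower number here means that less compound is needed, a higher number that more compound is needed for the effect: compound 2 gives > 10 mg/kg, which is a limit of the assay and not a number. Compound 1 `CCCCCCN1CCC(C(=O)Nc2cc(Cl)c(N)cc2OC)CC1` gives > 10 mg/kg in this assay, again a limit. Compound 3 `COc1cc(N)c(Cl)cc1NC(=O)C1CCN(Cc2ccccc2F)CC1` gives > 4 mg/kg in this assay, also a limit. Two of the values sit at the limit of > 10 mg/kg in this assay, at which 2 of the 3 values shown sit, and one at the limit of > 4 mg/kg in this assay, at which 1 of the 3 values shown sits. The steps a step that the two limits leave unreadable from compound 1 to compound 2, a step that the two limits leave unreadable from compound 1 to compound 3 and a step that the two limits leave unreadable from compound 2 to compound 3 therefore have no readable size. Compound 4 `COc1cc(N)c(Cl)cc1NC(=O)C1CCN(Cc2ccsc2)CC1` carries thiophen-3-yl in place of cyclobutyl on a saturated chain carbon bound to an amine nitrogen in a ring. Among the compounds with values here, no measured step bears on this change with a readable size, so neither direction nor size can be drawn from the series. Compound 4 is expected to give 15 mg/kg in this assay, within 5 mg/kg to 50 mg/kg, most likely again as a limit. The step that the limit leaves unreadable from compound 2 to compound 4 is estimated to stay within the scatter.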

Compound 4, dose for half-maximal effect: 3.4 mg/kg
Beside the measured number, compound 4's estimate is 4.4-fold (0.64 log units) above it, outside the stated range (below it).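

Compound 4 is the only compound shown with a number rather than a limit in this assay, so a substituent on a saturated chain carbon bound to an amine nitrogen in a ring can bring a readable dose. Thiophen-3-yl in place of cyclobutyl gives an at least 2.9-fold lower number from compound 2 to compound 4 (0.46 log units; beyond the scatter), and in place of pentyl it gives an at least 2.9-fold lower number from compound 1 to compound 4 (0.46 log units; beyond the scatter). In place of 2-fluorophenyl it gives only an at least 1.1-fold lower number from compound 3 to compound 4 (0.07 log units; that floor lies within the scatter), so no order between those two groups can be read.

Within the data shown here, the true sizes of these steps remain open, and the steps among the earlier compounds cannot be read: the limit of > 10 mg/kg in this assay, at which 2 of the 4 values shown sit. Whether thiophen-2-yl or unsubstituted phenyl would also give a number is open too.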